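A few compounds are considered here, and "the series" means these few. Any claim that something is new, unique, unknown or untested is made for them only; others in the source may bear on it.

Compound 1 `COC(=O)CCn1c2ccc([N+](=O)[O-])cc2c(=O)n1Cc1ccccc1` and compound 2 `CCOC(=O)CCCn1c2ccc([N+](=O)[O-])cc2c(=O)n1Cc1ccccc1` share one core, while compound 3 `COC(=O)CCOc1c2cc([N+](=O)[O-])ccc2nn1Cc1ccccc1` and compound 4 `CCOC(=O)CCCOc1c2cc([N+](=O)[O-])ccc2nn1Cc1ccccc1` share another; the difference between the two cores is not broken down here. In an ADME assay on L929 cells (Mus musculus) for cytotoxicity, read by resazurin assay, with a stated time of 48 h (a lower number here means that less compound is tolerated, a higher number that more compound is tolerated), compound 1 gives only a limit, > 256000 nM. In this assay compound 2 gives 78100 nM. The change (ethoxycarbonyl)methyl in place of methoxycarbonyl on a saturated chain carbon, two bonds along the chain from an aromatic nitrogen thus produced an at least 3.2-fold lower number from compound 1 to compound 2 (0.51 log units; beyond the scatter). In this assay compound 3 also sits at a limit, > 256000 nM. Two of the three values shown lie at that limit (the limit of > 256000 nM in this assay, at which 2 of the 3 values shown sit). Compound 4 carries the same kind of change, ((ethoxycarbonyl)methyl in place of methoxycarbonyl on a saturated chain carbon, two bonds along the chain from an oxygen on an aromatic ring), the place differing in that the chain carbon is two bonds from an oxygen on an aromatic ring rather than from an aromatic nitrogen. Beside the earlier step, a step of an at least 2.3-fold lower number from compound 3 to compound 4 (0.36 log units; beyond the scatter) is expected. That expectation rests on compound 2 and its value 78100 nM in this assay. Compound 4 is therefore estimated at 110000 nM, between 40000 nM and 256000 nM.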

Compound 4, concentration lethal to 50% of the cells: > 256000 nM
Compound 4 was reported as a limit (the forecaster's own chance of this, stated with the estimate: 35%); middle value at least 2.3-fold (0.36 log units) away from the limit.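

Both compound 3 and compound 4 are reported only as limits, so no step between them can be read in this assay: the limit of > 256000 nM in this assay, at which 3 of the 4 values shown sit.

Going by these compounds, whether (ethoxycarbonyl)methyl lowers the number on the core of compound 3 as it does on the core of compound 1 stays open.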